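This account rests on a few compounds, and the source may have more. Where it says the series, first, only, none or still open, it means among the compounds named here.

Compound 1 `CSc1nn2c(C)cc(C)nc2c1S(=O)(=O)c1ccc(O)cc1` and compound 2 `CNc1nn2c(C)cc(C)nc2c1S(=O)(=O)c1ccc(O)cc1` share one core and differ only in a single group; compound 3 `COCc1cc(C)nc2c(S(=O)(=O)c3ccccc3)c(SC)nn12` carries a different core, and the difference between the two cores is not broken down here. Compound 4 `CNc1nn2c(COC)cc(C)nc2c1S(=O)(=O)c1ccccc1` is built from compound 3 by the same kind of change that turns compound 1 into compound 2. In a functional assay on HEK293 cells for antagonist activity at 5-hydroxytryptamine receptor 6 (Homo sapiens), read by cAMP accumulation, with a stated time of 2 h (a higher number here means a weaker inhibitor, a lower number a stronger inhibitor), compound 1 gives 3.98 nM, and compound 2 gives 2 nM. The change between them is methylamino in place of methylsulfanyl on an aromatic carbon, which made the step of a 2.0-fold lower number from compound 1 to compound 2 (0.30 log units; within the scatter). In this assay compound 3 gives 155 nM, the highest of the three numbers. The change from compound 3 to compound 4 is methylamino in place of methylsulfanyl on an aromatic carbon; it is the same kind of change, with the group next to the place described as a group of 9 heavy atoms rather than simply as a large group. For compound 4 a step of about a 1.7-fold lower number from compound 3 to compound 4 (0.24 log units; within the scatter) is expected, because a 2.0-fold lower number from compound 1 to compound 2 (0.30 log units; within the scatter) shows that this change did little on the other core. Compound 4 is therefore estimated at 90 nM, expected to fall between 35 nM and 230 nM.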

Compound 4, inhibition constant: 7.59 nM
The estimate for compound 4 lay 12-fold (1.07 log units) above the measured number; measured number outside the range, below it.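

Putting methylamino in place of methylsulfanyl gave a 20-fold lower number from compound 3 to compound 4 (1.31 log units; beyond the scatter) in this assay. Set beside the same swap on the other core, this shows that the size of the step did not carry over from one core to the other: the same change on two cores in this assay, a 2.0-fold lower number (0.30 log units; within the scatter) from compound 1 to compound 2 and a 20-fold lower number (1.31 log units; beyond the scatter) from compound 3 to compound 4, 10-fold (1.01 log units) apart, beyond the scatter of two such steps It does not show why the two steps differ, since the two cores are not broken down into their single differences, and two pairs of compounds cannot say what the same swap would do on a third core.

The compounds shown leave open whether the larger step belongs to the core of compound 3 as a whole or to one part of it. They also leave open how the step would look with another group in the same place, such as a dimethylamino group, an ethylamino group or a plain amine.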